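Chloro on the Benzyl Group: an Expected Growth-Inhibition Change

A few compounds are considered here, and "the series" means these few. Any claim that something is new, unique, unknown or untested is made for them only; others in the source may bear on it.

Measured compounds:
Compound 1, `O=c1c2ccccc2[se]n1-c1nc(SCc2ccccc2)n[nH]1`, gives 32000 nM in a functional assay on SMMC-7721 cells (Homo sapiens) for antiproliferative activity, read by CCK-8 assay, with a stated time of 48 h; on this read-out higher numbers stand for weaker inhibition and lower numbers for stronger inhibition.
Compound 2, `Cc1cccc(CSc2n[nH]c(-n3[se]c4ccccc4c3=O)n2)c1`, gives 9040 nM in this assay.

Of these two, compound 1 has the higher number, meaning the weaker inhibition of cell growth. Within the data shown here, its only neighbour is compound 2, reached by a 3.5-fold lower number from compound 1 to compound 2 (0.55 log units; beyond the scatter), a change that lies beyond the usual scatter yet is modest in size.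

Compound 3, `O=c1c2ccccc2[se]n1-c1nc(SCc2ccc(Cl)cc2)n[nH]1`, differs from compound 1 by chloro in place of hydrogen on an aromatic carbon. Among the measured compounds shown here, the single step that bears on this is the methyl-for-hydrogen step just described, which lowered the number modestly. A substituent entering the same benzyl ring is therefore expected to give a similarly modest fall, with the caution that one example is slim evidence. Compound 3 is estimated at 13000 nM, with a range from 5000 nM to 35000 nM. This estimate corresponds to an expected 2.5-fold lower number from compound 1 to compound 3 (0.39 log units; beyond the scatter).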

Compound 3, half-maximal inhibitory concentration: 33900 nM
Compound 3: the middle estimate sits 2.6-fold (0.42 log units) below what was measured, within the range that was stated.
By their numbers in this assay, from the lowest: compound 2; then compounds 1 and 3 (each within the scatter of the next).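

In this assay, replacing benzyl with 4-chlorobenzyl leaves the result within the scatter (a 1.1-fold higher number from compound 1 to compound 3 (0.03 log units; within the scatter)), so adding a group to this ring does not by itself lower the number. The two substituted compounds also part ways (a 3.8-fold higher number from compound 2 to compound 3 (0.57 log units; beyond the scatter)), which shows that 3-methylphenyl and 4-chlorophenyl are not interchangeable here, although that step changes both the group and its place on the ring. No measurement shown here explains this difference.

The compounds shown leave open whether the lower number of compound 2 belongs to the methyl group itself or to where it sits on the ring. They also leave open how an amine, a methoxy group or a carboxylic acid on this ring would compare with methyl and chloro.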